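Three Inactive Amides and an Ethyl Analogue

The compounds below may be only part of what the source reports. "The series", "measured", "known", "first", "only" and "open" are said of these compounds alone.

Compound 1 `CNC(=O)c1cc(Oc2ccc(NC(=O)c3nccc(-c4cccc(Cl)c4)n3)cc2)ccn1`: > 100000 nM
Compound 2 `CNC(=O)c1cc(Oc2ccc(NC(=O)c3cc(-c4ccc(F)cc4)ncn3)cc2)ccn1`: > 100000 nM
Compound 3 `CNC(=O)c1cc(Oc2ccc(NC(=O)c3cc(-c4ccc(C(F)(F)F)cc4)ncn3)cc2F)ccn1`: > 100000 nM

In a functional assay on A549 cells (Homo sapiens) for cytotoxicity, read by MTT assay, with a stated time of 72 h (a lower number here means a stronger inhibitor, a higher number a weaker inhibitor), compound 1 reaches only the limit of the assay, > 100000 nM. Compound 2 likewise gives only a limit, > 100000 nM. Compound 3 again returns a limit, > 100000 nM, and not a number. Compound 3 thus stands nowhere apart from the others: all three values sit at the same limit (the limit of > 100000 nM in this assay, at which 3 of the 3 values shown sit), so no order among them can be read.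

Compound 4 `CCc1ccc(-c2cc(C(=O)Nc3ccc(Oc4ccnc(C(=O)NC)c4)c(F)c3)ncn2)cc1` differs from compound 3 in one place. The change is ethyl in place of trifluoromethyl on an aromatic carbon, on an aromatic carbon of a six-membered aromatic ring of carbon only.

For the measured compounds named here, no step between measured compounds exists here, and no measured analogue carries an ethyl group. The three limits give no foothold for a direction, so the expectation for compound 4 in this assay is that the change brings no step beyond the scatter, and that the assay most probably reports a limit once more. Compound 4 is therefore estimated at 150000 nM, within 50000 nM to 500000 nM, which means an expected step that the limit leaves unreadable from compound 3 to compound 4.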

Compound 4, half-maximal inhibitory concentration: 3390 nM
Beside the measured number, compound 4's estimate is 44-fold (1.65 log units) above it; measured number below the stated range.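

For the compounds shown here, replacing 4-(trifluoromethyl)phenyl with 4-ethylphenyl gives an at least 29-fold lower number from compound 3 to compound 4 (1.46 log units; beyond the scatter), and this yields the first value in this assay that is a number and not a limit. The step gives only a lower bound and not a full size, because compound 3 stands at a limit: the limit of > 100000 nM in this assay, at which 3 of the 4 values shown sit. It still shows that this one place, with the rest of the structure unchanged, can decide whether a compound gives a number in this assay, something compound 1 and compound 2 could not show, as each differs from compound 3 in more than one place.

From the compounds shown here alone, whether the gain is particular to ethyl stays open, since a methyl group, a longer chain such as propyl, an amine or a carboxylic acid at this place would each test it. The compounds shown also do not tell whether ethyl would have the same effect on the core of compound 1 or compound 2.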